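The source may hold more compounds than are shown below. What is called first, only, known or untested is meant among the compounds shown, and "the series" means these compounds.

Compound 1 `Fc1ccc2nc(-c3cnco3)n(C3CC3)c2c1` — > 10000 nM
Compound 2 `Fc1ccc2nc(-c3cn[nH]c3)n(C3CC3)c2c1` — 1670 nM
Compound 3 `Fc1ccc2nc(-c3cncnc3)n(C3CC3)c2c1` — 5380 nM

The three measured compounds share one core and differ only in the aromatic ring attached to it. In an ADME assay on cells for inhibition of cytochrome P450 11B1, mitochondrial (Homo sapiens), read by HPLC, with a stated time of 60 min (a lower number here means a stronger inhibitor, a higher number a weaker inhibitor), compound 1 gives > 10000 nM, which is a limit of the assay rather than a number (the limit of > 10000 nM in this assay, at which 1 of the 3 values shown sits). In this assay compound 2 gives 1670 nM, and compound 3 gives 5380 nM. Compound 3 therefore stands highest of the two actual numbers; the gap to the other one is a 3.2-fold higher number from compound 2 to compound 3 (0.51 log units; beyond the scatter). The remaining steps, an at least 5.9-fold lower number from compound 1 to compound 2 (0.77 log units; beyond the scatter) and an at least 1.8-fold lower number from compound 1 to compound 3 (0.26 log units; that floor lies within the scatter), likewise concern only the attached ring.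

Compound 4 `Fc1cc2nc(-c3cncnc3)n(C3CC3)c2cc1F` differs from compound 3 elsewhere: fluoro in place of hydrogen on an aromatic carbon. For the measured compounds named here, none of the measured steps touches the core in this way, so the measured series says nothing about how this change shifts the number. With no guidance in either direction, compound 4 is expected to give about 5000 nM, with a range from 2000 nM to 12000 nM. This estimate means a step of a 1.1-fold lower number from compound 3 to compound 4 (0.03 log units; within the scatter), expected to stay within the scatter.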

Compound 4, half-maximal inhibitory concentration: 2270 nM
The estimate for compound 4 lay 2.2-fold (0.34 log units) above the measured number; the range from low to high includes it.
By their numbers in this assay, from the lowest: compounds 2 and 4 (each within the scatter of the next); then compound 3. At a limit, above all of these: compound 1.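

Until now every change lay in the attached ring; here the shared core changes, on the six-membered aromatic ring of carbon only, ortho to a fluoro group. In this assay, fluoro in place of hydrogen at this place gives a 2.4-fold lower number from compound 3 to compound 4 (0.37 log units; beyond the scatter), so the core can shift the number too, and compound 4 is the stronger inhibitor of this pair. Nothing measured here explains why this step occurs.

For the compounds shown here, whether the same change would move the number with the 1H-pyrazol-4-yl ring of compound 2 remains open; here it is seen only with the pyrimidin-5-yl ring. Also open, from the compounds shown here alone, is how a chlorine, a methoxy group or a nitrile at this place would compare with fluoro.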